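Oxime ether tail: ethyl ester in place of the oxazole

The source may report more compounds than this note shows. Statements on the series, on what has been measured and on what is new or still open speak of the compounds shown alone.

Measured so far:
- compound 1, `C/C(=N\OCCF)c1ccc(Sc2cc(F)cc(C3CCOCC3)c2)cc1`: 40 nM
- compound 2, `CS/C(=N\O)c1ccc(Sc2cc(F)cc(C3CCOCC3)c2)cc1`: 190 nM
- compound 3, `COC(=O)c1cc(CO/N=C(\C)c2ccc(Sc3cc(F)cc(C4CCOCC4)c3)cc2)on1`: 100 nM

In a functional assay (blood) for inhibition, with Homo sapiens as the target (a higher number here means a weaker inhibitor, a lower number a stronger inhibitor), compound 3 holds the second highest of the three numbers. Its gap to compound 2 is within the usual scatter, so the two cannot be ordered; against compound 1 the step is real, a 2.5-fold higher number from compound 1 to compound 3 (0.40 log units; beyond the scatter).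

Compound 4, `CCOC(=O)CO/N=C(\C)c1ccc(Sc2cc(F)cc(C3CCOCC3)c2)cc1`, is not yet measured in this assay. The change from compound 3 is ethoxycarbonyl in place of 3-(methoxycarbonyl)-1,2-oxazol-5-yl on a saturated chain carbon bound to an oxygen on an unsaturated carbon.

Among the measured compounds shown here, only one measured step touches this place: a 2.5-fold higher number from compound 1 to compound 3 (0.40 log units; beyond the scatter), where a larger group in place of fluoromethyl gave a modestly higher number. The step of a 4.8-fold higher number from compound 1 to compound 2 (0.68 log units; beyond the scatter) sits on the other side of the molecule and does not bear here. Compound 4 carries a group at the tail that is smaller than the oxazole ester of compound 3, and the expectation is that the number falls back toward that of compound 1, so a modest step of a 1.7-fold lower number from compound 3 to compound 4 (0.22 log units; within the scatter) is estimated. For compound 4 the estimated value is 60 nM, with a range of 25 nM to 150 nM.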

Compound 4, half-maximal inhibitory concentration: 610 nM
Compound 4: the middle estimate sits 10-fold (1.01 log units) below what was measured; the whole stated range lies below it.
By their numbers in this assay, from the lowest: compound 1; then compounds 3 and 2 (each within the scatter of the next); then compound 4.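

In this assay, the number does not follow the size of the tail group: the smaller ethoxycarbonyl gives a 6.1-fold higher number from compound 3 to compound 4 (0.79 log units; beyond the scatter), and it also gives a 15-fold higher number from compound 1 to compound 4 (1.18 log units; beyond the scatter), the largest step at this position. Compound 4 is the weakest of the four, with a 3.2-fold higher number from compound 2 to compound 4 (0.51 log units; beyond the scatter), so this ester costs more than the change on the aromatic carbon that gives compound 2. The ester in the oxazole-bearing tail of compound 3 and the ester attached directly in compound 4 are therefore not interchangeable at this position, and no supporting data explain the difference.

Still open, on these data alone, is whether the loss belongs to the ethyl ester itself or to the absence of the ring. A carboxylic acid or a primary amide in place of ethoxycarbonyl, or an unsubstituted 1,2-oxazol-5-yl, would separate these readings.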